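Two measured conjugates and a nitrophenyl analogue

The source may report more compounds than this note shows. Statements on the series, on what has been measured and on what is new or still open speak of the compounds shown alone.

Compound 1 `CNC(=O)[C@@]12C[C@@H]1[C@@H](n1cnc3c(NCc4cccc(Cl)c4)nc(C#CCCC(=O)NCCNC(=O)CCCCC4SCC5NC(=O)NC54)nc31)[C@H](O)[C@@H]2O` and compound 2 `CNC(=O)[C@@]12C[C@@H]1[C@@H](n1cnc3c(NCc4cccc(Cl)c4)nc(C#CCCCCc4cn(-c5ccc(C(=O)O)cc5)nn4)nc31)[C@H](O)[C@@H]2O` share one core and differ only in the group at the end of the alkyne chain. In an assay on CHO cells for displacement of a labelled ligand from adenosine receptor A1 (Homo sapiens), read by scintillation counting, tested at 10 uM (a higher number here means more inhibition at the concentration tested (going by the name of the read-out), a lower number less inhibition), compound 1 gives 1%, and compound 2 gives 0%, the lower of the two numbers, though the pair lie within the scatter of each other. Compound 3 `CNC(=O)[C@@]12C[C@@H]1[C@@H](n1cnc3c(NCc4cccc(Cl)c4)nc(C#CCCCCc4cn(-c5cccc([N+](=O)[O-])c5)nn4)nc31)[C@H](O)[C@@H]2O` carries 3-nitrophenyl in place of 4-carboxyphenyl on an aromatic nitrogen. For the measured compounds named here, with no measured step to lean on, the account expects no change beyond the scatter in this assay, so that a number 2 percentage points higher from compound 2 to compound 3 (within the scatter) is estimated as essentially flat. Compound 3 is therefore expected to give about 2%, within a range from -8% to 12%.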

Compound 3, a percentage reported as inhibition, at one concentration (the size of the read-out at that concentration, not a potency): 8%
The estimate for compound 3 lay 6 percentage points below the measured number, within the range that was stated.
By their numbers in this assay, from the lowest: compounds 2, 1 and 3 (each within the scatter of the next).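

In this assay, for the compounds shown here, 3-nitrophenyl in place of 4-carboxyphenyl on an aromatic nitrogen gives a first measured step at this position (a number 8 percentage points higher from compound 2 to compound 3 (within the scatter)). This exchange removes the hydrogen-bond donor of the leaving group, yet the number stays within the scatter. Nothing measured here accounts for the result.

The compounds shown leave open whether a plain phenyl or an aminophenyl on this nitrogen would give a number beyond the scatter. The same question stands for a longer chain on the alkyne.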